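One Aromatic Group Swapped, One Measurement Awaited

The source may report more compounds than this note shows. Statements on the series, on what has been measured and on what is new or still open speak of the compounds shown alone.

Of the compounds shown here, three with a shared core have been tested in a functional assay on MCF7 cells (Homo sapiens) for cytotoxicity, read by MTT assay, with a stated time of 72 h; on this read-out higher numbers stand for weaker inhibition and lower numbers for stronger inhibition. There, compound 1 (`O=C(N/N=C/c1ccc([N+](=O)[O-])cc1)Nc1cc2c(Nc3ccc(F)c(Cl)c3)ncnc2cc1O[C@H]1CCOC1`) is reported as "not active" (no number reported), without a number. Compound 2 (`O=C(N/N=C/c1ccc(F)cc1Cl)Nc1cc2c(Nc3ccc(F)c(Cl)c3)ncnc2cc1O[C@H]1CCOC1`) gives 32200 nM, and compound 3 (`COc1cc(/C=N/NC(=O)Nc2cc3c(Nc4ccc(F)c(Cl)c4)ncnc3cc2O[C@H]2CCOC2)cc(OC)c1OC`) gives 26500 nM, so compound 3 stands within the usual scatter of compound 2.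

Compound 4 (`CCN(CC)c1ccc(/C=N/NC(=O)Nc2cc3c(Nc4ccc(F)c(Cl)c4)ncnc3cc2O[C@H]2CCOC2)c(O)c1`) keeps the core of compound 3 but carries a different group on the carbon with a double bond to nitrogen: 4-(diethylamino)-2-hydroxyphenyl in place of 3,4,5-trimethoxyphenyl on a carbon with a double bond to nitrogen. Among the measured compounds shown here, only one measured step bears on this change, a 1.2-fold lower number from compound 2 to compound 3 (0.08 log units; within the scatter). It altered the same place and stayed within the scatter. For the measured compounds named here, that is thin evidence, since no tested compound carries the entering group, and the group on compound 1 left no number at all. No step beyond the scatter is therefore expected in this assay, and the estimated step is a 1.2-fold lower number from compound 3 to compound 4 (0.08 log units; within the scatter). Compound 4 is expected at about 22000 nM, within an estimated range of 7000 nM to 60000 nM.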

Compound 4, half-maximal inhibitory concentration: 15600 nM
Compound 4: the middle estimate sits 1.4-fold (0.15 log units) above what was measured, within the range that was stated.
By their numbers in this assay, from the lowest: compounds 4, 3 and 2 (each within the scatter of the next, the first and the last beyond it).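

At the place on a carbon with a double bond to nitrogen, putting 4-(diethylamino)-2-hydroxyphenyl in place of 3,4,5-trimethoxyphenyl gives a 1.7-fold lower number from compound 3 to compound 4 (0.23 log units; within the scatter) in this assay, with a hydrogen-bond donor entering where the group that leaves has none. Among the compounds shown here, measured against 2-chloro-4-fluorophenyl, the same entering group gives a 2.1-fold lower number from compound 2 to compound 4 (0.31 log units; beyond the scatter), the first step at this place to pass the scatter, though only modestly. Nothing measured here accounts for that step.

The diethylamino and hydroxy groups appear only together on one ring, so the compounds shown leave open which of them, if either, goes with the lower number. Also open, on these data alone, is how a phenyl ring carrying a carboxylic acid or a morpholine would compare at this place.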